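Aryl substituent variation on the anilide end of the series

A few compounds are considered here, and "the series" means these few. Any claim that something is new, unique, unknown or untested is made for them only; others in the source may bear on it.

Compound 1 `CCc1ccc(C(=O)Nc2cccc(NC(=O)COc3ccc4c(=O)ccoc4c3)c2)cc1`, compound 2 `N#Cc1ccc(C(=O)Nc2cccc(NC(=O)COc3ccc4c(=O)ccoc4c3)c2)cc1` and compound 3 `COC(=O)c1ccc(C(=O)Nc2cccc(NC(=O)COc3ccc4c(=O)ccoc4c3)c2)cc1` share one core and differ only in the group on the terminal aromatic ring. In an assay on isolated protein for inhibition of Rho-associated protein kinase 1 (Homo sapiens), read by scintillation counting, radiometric assay and 33P incorporation, with a stated time of 40 min, in the presence of a further agent that is not named here (a lower number here means a stronger inhibitor, a higher number a weaker inhibitor), compound 1 gives 235 nM, compound 2 gives 123 nM and compound 3 gives 72 nM. Compound 3 carries the lowest number of the three: the step of a 3.3-fold lower number from compound 1 to compound 3 (0.51 log units; beyond the scatter) lies beyond the scatter, whereas a 1.7-fold lower number from compound 2 to compound 3 (0.23 log units; within the scatter) and a 1.9-fold lower number from compound 1 to compound 2 (0.28 log units; within the scatter) do not, so compound 3 and compound 2 cannot be ordered.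

Compound 4 `O=C(COc1ccc2c(=O)ccoc2c1)Nc1cccc(NC(=O)c2cccc([N+](=O)[O-])c2)c1` is the next case. The change from compound 3 is 3-nitrophenyl in place of 4-(methoxycarbonyl)phenyl on a carbonyl carbon. Among the compounds with values here, no measured step covers this swap; the three steps so far only show that exchanging one group for another on that aromatic carbon moves this assay by modest amounts at most, and that the methoxycarbonyl group carried the lowest number. Compound 4 is therefore expected to give a number near or somewhat above compound 3, with a 1.8-fold higher number from compound 3 to compound 4 (0.26 log units; within the scatter) as the estimated step. Compound 4 is estimated at 130 nM in this assay, within 50 nM to 350 nM.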

Compound 4, half-maximal inhibitory concentration: 528 nM
Beside the measured number, compound 4's estimate is 4.1-fold (0.61 log units) below it, outside the stated range (above it).
By their numbers in this assay, from the lowest: compounds 3, 2 and 1 (each within the scatter of the next, the first and the last beyond it); then compound 4.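

In this assay the aryl group on the carbonyl carbon moves the number further than the exchanges among the first three compounds did: a 7.3-fold higher number from compound 3 to compound 4 (0.87 log units; beyond the scatter) and a 4.3-fold higher number from compound 2 to compound 4 (0.63 log units; beyond the scatter) both exceed every earlier step, and a 2.2-fold higher number from compound 1 to compound 4 (0.35 log units; beyond the scatter) is also beyond the scatter, leaving compound 4 the weakest of the four. The 3-nitrophenyl group differs from the three other aryl groups in both its substituent and the number of that substituent on the ring, so this swap changes two things that these compounds cannot separate. Nothing available bears on the reason for this result.

From the compounds shown here alone, whether the higher number follows the nitro group or its place on the ring stays open. Also open, going by these compounds, is how an amine, a carboxylic acid or a longer alkyl chain on the terminal ring would read in this assay on the shared core.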